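Fluoro in Place of Acetyl: Three Measured, One Expected

The compounds below may be only part of what the source reports. "The series", "measured", "known", "first", "only" and "open" are said of these compounds alone.

The measured compounds and their values:
Compound 1, `CC(=O)c1ccccc1NC(=O)N[C@H](C)c1ccccc1`, gives 96%.
Compound 2, `CC(=O)c1cccc(NC(=O)N[C@H](C)c2ccccc2)c1`, gives 98%.
Compound 3, `C[C@@H](NC(=O)Nc1ccccc1F)c1ccccc1`, gives 97%.

All three were tested in an ADME assay on the whole organism with Oryza sativa as the target, tested at 0.1 uM; on this read-out higher numbers stand for a weaker effect at the one concentration tested and lower numbers for a stronger effect. In this assay compound 1 gives 96%, compound 2 gives 98% and compound 3 gives 97%; none of the three is separated from the others by more than the usual scatter, so no order among them can be read from these numbers.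

Compound 1 and compound 2 share the same atoms joined differently; the difference between the two cores is not broken down here. Compound 3 arises from compound 1 by fluoro in place of acetyl on an aromatic carbon. That change produced a number 1 percentage points higher from compound 1 to compound 3 (within the scatter), a step that sits inside the scatter.

Compound 4, `C[C@@H](NC(=O)Nc1cccc(F)c1)c1ccccc1`, has not yet been measured. It arises from compound 2 by fluoro in place of acetyl on an aromatic carbon. Among the measured compounds shown here, this is the same kind of change as the one from compound 1 to compound 3, not the same change: in the earlier pair the place is ortho to a large group, whereas here it is meta to a large group.

For compound 4 the step from compound 2 is expected to be a number 1 percentage points lower from compound 2 to compound 4 (within the scatter), resting on the step of a number 1 percentage points higher from compound 1 to compound 3 (within the scatter) that the same kind of change gave between compound 1 and compound 3. Compound 4 is therefore estimated at 97%, with an expected range from 90% to 100%.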

Compound 4, a percentage reported as activity, at one concentration (the size of the read-out at that concentration, not a potency): 99%
Compound 4: middle estimate off by 2 percentage points, on the low side, and the stated range covers the measured number.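

In this assay the exchange of acetyl for fluoro on an aromatic carbon, here meta to a large group, gave a number 1 percentage points higher from compound 2 to compound 4 (within the scatter) and so left the read-out of compound 4 unresolved from that of compound 2. Set beside the earlier step on the other core, the new step agrees with it, and on these two cores the change carries over without a difference that can be read: the same change on two cores in this assay, a number 1 percentage points higher (within the scatter) from compound 1 to compound 3 and a number 1 percentage points higher (within the scatter) from compound 2 to compound 4, 0 percentage points apart, within the scatter of two such steps. Among the compounds shown here, this shows only that the change gave no step beyond the scatter on either core; it does not show that a step of real size would carry over in the same way, and two pairs of compounds cannot establish a rule for the whole series.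

The compounds shown leave open whether any other group on that aromatic carbon, such as an amine, a carboxylic acid or a nitrile, would move the read-out beyond the scatter on either core. They also leave open whether a longer chain elsewhere on the shared core would separate any compound from the others in this assay, and whether the exchange of acetyl for fluoro would then carry over as it does here.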